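A few compounds are considered here, and "the series" means these few. Any claim that something is new, unique, unknown or untested is made for them only; others in the source may bear on it.

Measured compounds:
Compound 1 `COc1ccc(-n2c(C)nc3c(NC(C4CC4)C4CC4)nc(C)nc32)cc1`: 19 nM
Compound 2 `COCc1nc2c(NC(C3CC3)C3CC3)nc(C)nc2n1-c1ccc(OC)cc1`: 157 nM
Compound 3 `Cc1nc(NC(C2CC2)C2CC2)c2nc(C)n(-c3ccc(S(C)(=O)=O)cc3)c2n1`: 140 nM

In a functional assay on CHO cells for antagonist activity at corticotropin-releasing factor receptor 1 (Homo sapiens), read by cAMP accumulation (on this read-out lower numbers stand for stronger inhibition and higher numbers for weaker inhibition), compound 1 gives 19 nM, compound 2 gives 157 nM and compound 3 gives 140 nM. Compound 3 thus stands second highest of the three numbers; its nearest neighbour is compound 2, which lies within the scatter of it, while compound 1 lies furthest away, beyond the scatter. Two single-point steps connect these compounds. From compound 1 to compound 2 the change is an 8.3-fold higher number from compound 1 to compound 2 (0.92 log units; beyond the scatter), and from compound 1 to compound 3 it is a 7.4-fold higher number from compound 1 to compound 3 (0.87 log units; beyond the scatter).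

Compound 4 `CCOc1ccc(-n2c(C)nc3c(NC(C4CC4)C4CC4)nc(C)nc32)cc1` has not yet been measured in this assay. Its change from compound 3 is ethoxy in place of methylsulfonyl on an aromatic carbon. Going by the values given here, of the measured steps, only the one from compound 1 to compound 3 bears on it: that step replaced methoxy with methylsulfonyl at the same aromatic carbon and raised the number well beyond the scatter. Among the compounds with values here, compound 4 reverses that replacement, though with ethoxy rather than methoxy, and no measured step tells how ethoxy compares with methoxy. A fall in the number, close to the size of the step from compound 1 to compound 3, is therefore expected, with some allowance for the untested ethoxy. The expected step is a 5.6-fold lower number from compound 3 to compound 4 (0.75 log units; beyond the scatter). Compound 4 is expected to give 25 nM, with a range from 10 nM to 80 nM.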

Compound 4, inhibition constant: 20 nM
Beside the measured number, compound 4's estimate is 1.3-fold (0.10 log units) above it; measured number inside the range.
By their numbers in this assay, from the lowest: compounds 1 and 4 (each within the scatter of the next); then compounds 3 and 2 (each within the scatter of the next).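

At the aromatic carbon para to a large group, ethoxy in place of methylsulfonyl gives a 7.0-fold lower number from compound 3 to compound 4 (0.85 log units; beyond the scatter), which shows that the number seen with methoxy in this assay does not depend on methoxy itself and is also reached with ethoxy. Methyl in place of hydrogen on the saturated chain carbon bound to the oxygen gives a 1.1-fold higher number from compound 1 to compound 4 (0.02 log units; within the scatter), so compounds 1 and 4 stand level and this position accepts ethoxy as readily as methoxy in this read-out. No supporting data are available to account for either step.

On these data alone, whether a longer chain such as butoxy, an amine or a carboxylic acid at this aromatic carbon would keep the number level with compounds 1 and 4 remains open. Also open, as far as these compounds go, is how ethoxy would behave alongside the methoxy group on the saturated chain carbon that separates compound 2 from compound 1, as these two places are read here only one at a time.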